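From 2-bromophenyl to 4-methylphenyl on an amine nitrogen

The compounds below may be only part of what the source reports. "The series", "measured", "known", "first", "only" and "open" are said of these compounds alone.

Measured compounds:
Compound 1 `CC1CC/C(=N\Nc2ccccc2)c2ncc(C(N)=O)c(=O)n21` gives in a functional assay on the whole organism for inhibition, with Rattus norvegicus as the target (on this read-out higher numbers stand for an effect only at larger amounts of compound and lower numbers for an effect already at smaller amounts), only the limit > 1000 umol/kg.
Compound 2 `CC1CC/C(=N\Nc2ccccc2Br)c2ncc(C(=O)O)c(=O)n21` gives in this assay only the limit > 320 umol/kg.
Compound 3 `CCOc1ccc(N/N=C2\CC[C@H](C)n3c2ncc(C(=O)O)c3=O)cc1` gives in this assay only the limit > 100 umol/kg.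

Each of these results is a limit of the assay and not a number, so none of the three measured compounds has an actual dose for half-maximal inhibition. Compound 2 stands at the limit of > 320 umol/kg in this assay, at which 1 of the 3 values shown sits. The two others sit at the limit of > 1000 umol/kg in this assay, at which 1 of the 3 values shown sits, and (the limit of > 100 umol/kg in this assay, at which 1 of the 3 values shown sits), so all three measured values are limits.

Compound 4 `Cc1ccc(N/N=C2\CCC(C)n3c2ncc(C(=O)O)c3=O)cc1` differs from compound 2 in one place: 4-methylphenyl in place of 2-bromophenyl on an amine nitrogen. For the measured compounds named here, no step between two measured compounds with a real number is available, so the size of this change cannot be read from the data. Since every measured compound reached only a limit, the expected step in this assay is a number no higher from compound 2 to compound 4 (the limit leaves the size open), meaning no change beyond the scatter. Compound 4 is expected to give 320 umol/kg, within a range from 100 umol/kg to 1000 umol/kg, and most likely only another limit.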

Compound 4, dose for 50% inhibition: > 1000 umol/kg
Compound 4: no number, only a limit; the forecaster's own chance of this, stated with the estimate: 80%; at least 3.1-fold (0.49 log units) between middle value and limit.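

For the compounds shown here, compound 2 and compound 4 each give only a limit in this assay, and no step between them can be read. The compounds shown leave open what dose any of them needs for an effect, and whether exchanging 2-bromophenyl for 4-methylphenyl changes that dose at all.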